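A chain replaces a ring on the aromatic nitrogen

A few compounds are considered here, and "the series" means these few. Any claim that something is new, unique, unknown or untested is made for them only; others in the source may bear on it.

Measured compounds:
- Compound 1 `N[C@H]1CC[C@H](Nc2c(C(=O)NCc3ccc(Oc4ccccc4)cc3)nc(Br)c3cccnc23)CC1` — in a functional assay on SK-BR-3 cells (Homo sapiens) for cytotoxicity, read by MTT assay, with a stated time of 72 h (a lower number here means a stronger inhibitor, a higher number a weaker inhibitor), compound 1 gives "not determined" (no result reported).
- Compound 2 `N[C@H]1CC[C@H](Nc2c(C(=O)NCc3ccc(F)cc3)nc(Br)c3cccnc23)CC1` — in this assay compound 2 gives 2000 nM.
- Compound 3 `N[C@H]1CC[C@H](Nc2c(C(=O)Nc3ccccc3)nc(Br)c3cccnc23)CC1` — in this assay compound 3 gives 2000 nM.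

Compound 2 stands level with compound 3: the step of no change at the digits printed from compound 2 to compound 3 (within the scatter) lies within the scatter, so nothing separates the two in this assay. Compound 1 contributes no number.

Compound 4 `CN(C)CCCNc1c(C(=O)NCc2ccc(F)cc2)nc(Br)c2cccnc12` differs from compound 2 in one place: 3-(dimethylamino)propyl in place of 4-aminocyclohexyl on a nitrogen on an aromatic ring. For the measured compounds named here, the only measured step, from compound 2 to compound 3, concerns the amide-type nitrogen on the other side of the shared core, and it was flat. It does not touch the nitrogen on the aromatic ring where compound 4 changes. Going by the values given here, no measured step therefore bears on the move from compound 2 to compound 4, and the data give no direction for it.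

With nothing to lean on but the value of compound 2, the expectation for compound 4 is a step of a 1.5-fold higher number from compound 2 to compound 4 (0.18 log units; within the scatter) in this assay, which is no step beyond the scatter but carries wide uncertainty. Compound 4 is estimated at 3000 nM, within 700 nM to 15000 nM.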

Compound 4, half-maximal inhibitory concentration: 1000 nM
Compound 4: the middle estimate sits 3.0-fold (0.48 log units) above what was measured; measured number inside the range.
By their numbers in this assay, from the lowest: compounds 4, 2 and 3 (each within the scatter of the next).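

For the compounds shown here, this is the first measured change at the nitrogen on an aromatic ring, and in this assay it gives a 2.0-fold lower number from compound 2 to compound 4 (0.30 log units; within the scatter), so the two compounds cannot be told apart here. For this pair, then, the six-membered carbon ring, its defined stereocentres and the hydrogen-bond donor of 4-aminocyclohexyl can all give way to the open, ringless 3-(dimethylamino)propyl chain with no change beyond the scatter, which means this cytotoxicity read-out does not depend on keeping that ring when the 4-fluorobenzyl amide is in place. No measurement available here explains why the two groups score alike.

The compounds shown do not say whether the amine at the end of the chain matters, which a plain propyl chain or one ending in a hydroxyl group would test, or whether a shorter 2-(dimethylamino)ethyl or a longer 4-(dimethylamino)butyl chain would keep the same level. Going by these compounds alone, it also remains open whether 3-(dimethylamino)propyl would behave the same way alongside the phenyl amide of compound 3, since each of these two changes has so far been seen only on its own.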